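Working notes: replacing 2-hydroxyethyl on the shared core

The compounds below may be only part of what the source reports. "The series", "measured", "known", "first", "only" and "open" are said of these compounds alone.

In a functional assay on DU-145 cells (Homo sapiens) for cytotoxicity, read by MTT assay (on this read-out lower numbers stand for stronger inhibition and higher numbers for weaker inhibition), compound 3 `CC(C)=CC[C@@H](OCCO)C1=CC(=O)c2c(O)ccc(O)c2C1=O` gives 9900 nM, the lowest number of the three measured, while compound 1 `CCC(CO[C@H](CC=C(C)C)C1=CC(=O)c2c(O)ccc(O)c2C1=O)OC(C)=O` gives 25400 nM and compound 2 `CC(C)=CC[C@@H](OC(=O)C1CCOC1)C1=CC(=O)c2c(O)ccc(O)c2C1=O` gives 47500 nM. Compound 4 `CCC(O)(CC)CC(=O)O[C@H](CC=C(C)C)C1=CC(=O)c2c(O)ccc(O)c2C1=O` is still unmeasured, and its change is (2-ethyl-2-hydroxybutyl)carbonyl in place of 2-hydroxyethyl on an oxygen on a saturated carbon. For the measured compounds named here, compound 2 also holds a carbonyl-ended group, (oxolan-3-yl)carbonyl, on an oxygen on a saturated carbon, so the closest precedent is a 4.8-fold lower number from compound 2 to compound 3 (0.68 log units; beyond the scatter). The step of a 2.6-fold lower number from compound 1 to compound 3 (0.41 log units; beyond the scatter) also ends at the lower number, and a 1.9-fold higher number from compound 1 to compound 2 (0.27 log units; within the scatter) separates neither compound. A reversal of similar size is expected in this assay, namely a 3.0-fold higher number from compound 3 to compound 4 (0.48 log units; beyond the scatter). For compound 4 the estimate is 30000 nM, with an expected range of 12000 nM to 70000 nM.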

Compound 4, half-maximal inhibitory concentration: 67000 nM
Estimate against measurement, compound 4: 2.2-fold (0.35 log units) below, within the range that was stated.
By their numbers in this assay, from the lowest: compound 3; then compounds 1, 2 and 4 (each within the scatter of the next, the first and the last beyond it).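

On an oxygen on a saturated carbon, a second carbonyl-ended group in place of 2-hydroxyethyl gives a 6.8-fold higher number from compound 3 to compound 4 (0.83 log units; beyond the scatter) in this assay, so the earlier result is not confined to (oxolan-3-yl)carbonyl. With 2-ethyl-2-hydroxybutyl in place of oxolan-3-yl on a carbonyl carbon, a 1.4-fold higher number from compound 2 to compound 4 (0.15 log units; within the scatter) separates neither compound, whereas a 2.6-fold higher number from compound 1 to compound 4 (0.42 log units; beyond the scatter) separates (2-ethyl-2-hydroxybutyl)carbonyl from 2-acetoxybutyl. Nothing available bears on the cause of these steps.

Still open, as far as these compounds go, is whether 3-hydroxypropyl or 2-aminoethyl in place of 2-hydroxyethyl on this oxygen would hold the low number of compound 3 9900 nM.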